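This account rests on a few compounds, and the source may have more. Where it says the series, first, only, none or still open, it means among the compounds named here.

In a functional assay on the whole organism for antagonist activity, with Mus musculus as the target (a lower number here means that less compound is needed, a higher number that more compound is needed for the effect), compound 1 (`CCC(=O)N(c1ccc(Cl)c(Cl)c1)C1CCCC1O`) gives 9 mg/kg and compound 2 (`CCCC(=O)N(c1ccccc1)C1CCCC1N(C)C`) gives 10 mg/kg, two values within the usual scatter of each other. Compound 3 (`CCC(=O)N(c1ccc(Cl)c(Cl)c1)C1CCCC1N(CC)CC`) keeps the core of compound 1 but has diethylamino in place of hydroxy on a saturated ring carbon. Among the measured compounds shown here, no measured step shows what this swap does in this assay, so compound 2 at 10 mg/kg is the only other guide. The a 1.1-fold higher number from compound 1 to compound 3 (0.05 log units; within the scatter) is expected to stay within the scatter, in neither direction. Compound 3 is estimated at 10 mg/kg, with an expected range from 3 mg/kg to 35 mg/kg.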

Compound 3, dose for half-maximal effect: 0.03 mg/kg
Compound 3: the middle estimate sits 330-fold (2.52 log units) above what was measured, and the stated range ends above it.
By their numbers in this assay, from the lowest: compound 3; then compounds 1 and 2 (each within the scatter of the next).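

In this assay, the group on this saturated ring carbon, next to the ring atom that bears a large group, proves decisive: diethylamino in place of hydroxy gives a 300-fold lower number from compound 1 to compound 3 (2.48 log units; beyond the scatter), so far less compound is needed for the effect. The earlier compounds shown here, whose values lay within the scatter of each other, gave no sign of a change this large. No measurement shown here explains the step. From the compounds shown here alone, it remains open whether the nitrogen or the size of the new group matters more. A plain amino group or a pentyl chain at this place would help separate the two.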